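The compounds below may be only part of what the source reports. "The series", "measured", "known", "first", "only" and "open" are said of these compounds alone.

Measured so far:

Compound 1 `O=S(=O)(Nc1ccc(-c2nc3ccccc3o2)cc1)c1ccccc1C(F)(F)F` gives > 100000 nM in an ADME assay on HEK293 cells (Homo sapiens) for cytotoxicity, read by resazurin assay, with a stated time of 48 h (a lower number here means that less compound is tolerated, a higher number that more compound is tolerated), which is a limit of the assay rather than a number.

Compound 2 `COc1ccc(Cl)cc1S(=O)(=O)Nc1ccc(-c2nc3ccccc3o2)cc1` gives 75000 nM in this assay.

Compound 3 `O=S(=O)(Nc1ccc2oc(-c3ccccc3)nc2c1)c1cccc(C(F)(F)F)c1` gives > 100000 nM in this assay, again a limit and not a number.

Among the measured compounds shown here, compound 2 is therefore the only compound of the three with an actual number in this assay. Compound 1 sits at the limit of > 100000 nM in this assay, at which 2 of the 3 values shown sit. Compound 3 sits at that same limit. All three share the same core, and all are tolerated by the cells at high concentration.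

Compound 4 `C=Cc1ccc(S(=O)(=O)Nc2ccc(-c3nc4ccccc4o3)cc2)cc1` has not yet been measured. It differs from compound 2 in one place: 4-vinylphenyl in place of 5-chloro-2-methoxyphenyl on a sulfonyl sulfur. For the measured compounds named here, no pair of measured compounds differing in a single place is available, so the size of this step cannot be read from a measured example. Given that all three measured compounds sit at or near the top of the concentration range in this assay, the expectation is a step in this assay no larger than the usual scatter, in either direction. Compound 4 is estimated at 90000 nM, within a range from 40000 nM to 200000 nM. The expected step is a 1.2-fold higher number from compound 2 to compound 4 (0.08 log units; within the scatter), and a limit rather than a number is quite possible.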

Compound 4, half-maximal cytotoxic concentration: > 100000 nM
Compound 4: a limit, no number; the forecaster's own chance of this, stated with the estimate: 50%; middle value at least 1.1-fold (0.04 log units) away from the limit.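

Among the compounds shown here, this is the first step that can be read at this position, on a sulfonyl sulfur, and in this assay it is an at least 1.3-fold higher number from compound 2 to compound 4 (0.12 log units; that floor lies within the scatter). Only a floor is known, so the true size of the change from 5-chloro-2-methoxyphenyl to 4-vinylphenyl could be small or much larger, but the swap does not bring the number down into a lower range. Compound 4 now stands with compound 1 and compound 3 at a limit rather than a number: the limit of > 100000 nM in this assay, at which 3 of the 4 values shown sit.

As far as these compounds go, how far these compounds lie beyond that limit stays unknown. From the compounds shown here alone, it also remains open whether an amine or a carboxylic acid on the ring attached to the sulfonyl sulfur would give a lower number in this assay.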